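A few compounds are considered here, and "the series" means these few. Any claim that something is new, unique, unknown or untested is made for them only; others in the source may bear on it.

For the measured compounds named here, compound 2 `COc1ccc(-c2nc3cccc(-c4cc(OC)c(OC)c(OC)c4)c3o2)cc1F` gives 1800 nM in a functional assay on A549 cells (Homo sapiens) for antiproliferative activity, read by MTT assay, with a stated time of 48 h (on this read-out lower numbers stand for stronger inhibition and higher numbers for weaker inhibition), the lowest of the two numbers so far; its nearest neighbour, compound 1 `COc1cccc(-c2nc3cccc(-c4cc(OC)c(OC)c(OC)c4)c3o2)c1`, gives 3500 nM. Going by the values given here, the single step between measured compounds, a 1.9-fold lower number from compound 1 to compound 2 (0.29 log units; within the scatter), stays within the scatter. Compound 3 `COc1cc(-c2nc3cccc(-c4cc(OC)c(OC)c(OC)c4)c3o2)ccc1O` is not yet measured. Its change from compound 2 is 4-hydroxy-3-methoxyphenyl in place of 3-fluoro-4-methoxyphenyl on an aromatic carbon. Among the compounds with values here, only one measured step, a 1.9-fold lower number from compound 1 to compound 2 (0.29 log units; within the scatter), touches the same aromatic carbon, and it lies within the scatter; no measured pair sets a 4-hydroxy-3-methoxyphenyl against a 3-fluoro-4-methoxyphenyl, so the data give no direction for the present exchange. The expected step is therefore a 1.2-fold higher number from compound 2 to compound 3 (0.09 log units; within the scatter), one no larger than the scatter, and this expectation carries a broader uncertainty than a repeat measurement would. Compound 3 is estimated at 2200 nM, with a range from 700 nM to 7000 nM.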

Compound 3, half-maximal inhibitory concentration: 15700 nM
Compound 3: the middle estimate sits 7.1-fold (0.85 log units) below what was measured; measured number above the stated range.
By their numbers in this assay, from the lowest: compounds 2 and 1 (each within the scatter of the next); then compound 3.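

At this aromatic carbon, next to the ring nitrogen and next to the ring oxygen, the choice of aryl group now registers in this assay: 4-hydroxy-3-methoxyphenyl in place of 3-fluoro-4-methoxyphenyl gives an 8.7-fold higher number from compound 2 to compound 3 (0.94 log units; beyond the scatter) and so clears the scatter, which the earlier step at this carbon did not. Hydroxy in place of hydrogen on the aryl ring points the same way with a 4.5-fold higher number from compound 1 to compound 3 (0.65 log units; beyond the scatter) as a second step beyond the scatter, leaving compound 3 as the weakest of the three. Nothing available bears on why the number rises with this change.

As far as these compounds go, whether the rise is specific to hydroxy or would also follow an amine or a carboxylic acid on the same ring carbon stays open. The separate contributions of fluoro and methoxy placement in compound 2 also remain unresolved.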